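Ring-Closed Side Chain on an Antiproliferative Core

This account rests on a few compounds, and the source may have more. Where it says the series, first, only, none or still open, it means among the compounds named here.

Compound 1: `CCC(C)Cn1c(Cc2cc(OC)c(OC)c(OC)c2)nc2c(N)ncnc21` gives 61700 nM in a functional assay on MCF7 cells (Homo sapiens) for antiproliferative activity; a higher number here means a weaker inhibitor, a lower number a stronger inhibitor.
Compound 2: `CCCCn1c(Cc2cc(OC)c(OC)c(OC)c2Cl)nc2c(N)ncnc21` gives 19100 nM in this assay.

Of the two measured compounds, compound 1 stands at the higher number, so it is the weaker inhibitor; compound 2 sits well below it, and that gap lies beyond the usual scatter. Compound 2 differs from compound 1 in more than one place, so its value says nothing on its own about any single change.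

Compound 3, `COc1cc(Cc2nc3c(N)ncnc3n2CC2(C)CC2)cc(OC)c1OC`, keeps the core of compound 1 and alters only the side chain on the aromatic nitrogen: 1-methylcyclopropyl in place of sec-butyl on a saturated chain carbon bound to an aromatic nitrogen. The group that leaves and the group that enters are of the same size, and neither carries donors, acceptors or charge. Among the measured compounds shown here, with no measured step on a comparable change, the expectation is for little movement, a 1.2-fold lower number from compound 1 to compound 3 (0.09 log units; within the scatter), in either direction and likely inside the scatter. Compound 3 is therefore estimated at 50000 nM, within a range from 20000 nM to 150000 nM.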

Compound 3, half-maximal inhibitory concentration: 112000 nM
Beside the measured number, compound 3's estimate is 2.2-fold (0.35 log units) below it; the measured number falls inside the stated range.
By their numbers in this assay, from the lowest: compound 2; then compounds 1 and 3 (each within the scatter of the next).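

Among the compounds shown here, compound 3 gives the first comparison here that changes a single place, and in this assay it reads as a 1.8-fold higher number from compound 1 to compound 3 (0.26 log units; within the scatter) for the exchange of sec-butyl for 1-methylcyclopropyl. For the compounds shown here, on a saturated chain carbon bound to an aromatic nitrogen, then, closing this side chain into a three-membered ring, with the same count of heavy atoms, produces no step that stands clear of the scatter. No measurement shown here offers an explanation for this result.

The compounds shown leave open whether a different kind of group at this place, such as a longer chain or an amine, would move the number beyond the scatter. Compound 2 differs from compound 1 in more than one place, so which of its changes goes with its value also remains unsettled.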